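The source may hold more compounds than are shown below. What is called first, only, known or untested is meant among the compounds shown, and "the series" means these compounds.

Three compounds of this series carry a measurement in a functional assay on DLD-1 cells (Homo sapiens) for cytotoxicity, read by MTT assay; on this read-out higher numbers stand for weaker inhibition and lower numbers for stronger inhibition. Compound 1 `CCOc1ccc(C=C(C(=O)/C=C/c2ccc(O)c(OC)c2)C(=O)/C=C/c2ccc(O)c(OC)c2)cc1OCC` gives 4120 nM. Compound 2 `COc1cc(/C=C/C(=O)C(=Cc2ccccc2)C(=O)/C=C/c2ccc(O)c(OC)c2)ccc1O` gives 5450 nM; the change from compound 1 to compound 2 is phenyl in place of 3,4-diethoxyphenyl on a double-bonded chain carbon bound to a double-bonded chain carbon and it made a 1.3-fold higher number from compound 1 to compound 2 (0.12 log units; within the scatter). Compound 3 `CCOc1cc(/C=C/C(=O)C(=Cc2ccc(OCC)c(OCC)c2)C(=O)/C=C/c2ccc(O)c(OCC)c2)ccc1O` gives 3450 nM; how the core of compound 3 differs from the core of compound 1 is not broken down here, and the two values sit within the scatter of each other. Compound 4 `CCOc1cc(/C=C/C(=O)C(=Cc2ccccc2)C(=O)/C=C/c2ccc(O)c(OCC)c2)ccc1O` remains to be measured. Its difference from compound 3 is phenyl in place of 3,4-diethoxyphenyl on a double-bonded chain carbon bound to a double-bonded chain carbon, the same change as that from compound 1 to compound 2, occurring twice among the compounds shown. Because a 1.3-fold higher number from compound 1 to compound 2 (0.12 log units; within the scatter) lies within the scatter, a step of similar size is expected here as well: a 1.3-fold higher number from compound 3 to compound 4 (0.12 log units; within the scatter). Compound 4 is accordingly estimated at 4500 nM, expected to fall between 2500 nM and 8000 nM.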

Compound 4, half-maximal inhibitory concentration: 5060 nM
For compound 4 the middle estimate is 1.1-fold (0.05 log units) below the measured one; measured number inside the range.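

Putting phenyl in place of 3,4-diethoxyphenyl on a double-bonded chain carbon bound to a double-bonded chain carbon gives a 1.5-fold higher number from compound 3 to compound 4 (0.17 log units; within the scatter) in this assay. The change reads alike on both cores: the same change on two cores in this assay, a 1.3-fold higher number (0.12 log units; within the scatter) from compound 1 to compound 2 and a 1.5-fold higher number (0.17 log units; within the scatter) from compound 3 to compound 4, 1.1-fold (0.04 log units) apart, within the scatter of two such steps

This shows that the step carries over between these two cores, but each step lies within the scatter, and neither shows that removing the ethoxy groups has a real effect on the read-out. The compounds shown leave open whether another group at this place, such as an aminophenyl or a carboxyphenyl, would move the number beyond the scatter. Going by these compounds, it also remains open whether the step holds on a core with a longer chain, such as propoxy, in place of the ethoxy groups of compound 3.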